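The compounds below may be only part of what the source reports. "The series", "measured", "known", "first", "only" and "open" are said of these compounds alone.

Compound 1 `Nc1ccc2cccc(OCC3CCCC3)c2n1` and compound 2 `CCCCOc1cccc2ccc(N)nc12` share one core and differ only at the chain carried by the oxygen on the aromatic ring. In an assay on cells with melanin-concentrating hormone receptor 1 (Homo sapiens) as the target, read by radioligand binding (a higher number here means a weaker inhibitor, a lower number a stronger inhibitor), compound 1 gives 53 nM, and compound 2 gives 789 nM. Among the compounds with values here, the single step between them, a 15-fold higher number from compound 1 to compound 2 (1.17 log units; beyond the scatter), is the only comparison available. Among the two numbers so far, compound 2 stands at the higher one, the weaker end.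

Compound 3 `CC(C)=CCOc1cccc2ccc(N)nc12` is not yet measured. It differs from compound 2 by 2-methylprop-1-en-1-yl in place of propyl on a saturated chain carbon bound to an oxygen on an aromatic ring. Within the data shown here, the one measured step bears on it only indirectly: it shows that the chain on the oxygen matters, and that the propyl of compound 2 is the poorer of the two chains tried. The 2-methylprop-1-en-1-yl that enters brings one more carbon and a double bond outside the aromatic rings, moving away from the propyl that gave the weaker number. A step downward in this assay is expected for compound 3, smaller than the step between compound 1 and compound 2, of about a 3.2-fold lower number from compound 2 to compound 3 (0.50 log units; beyond the scatter). Compound 3 is therefore estimated at 250 nM, within 80 nM to 800 nM.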

Compound 3, half-maximal inhibitory concentration: > 2000 nM
Compound 3 ended at the assay's limit; the forecaster's own chance of this, stated with the estimate: 2%; middle value at least 8.0-fold (0.90 log units) from the limit.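

In this assay compound 3 gives > 2000 nM, which is a limit of the assay and not a number: the limit of > 2000 nM in this assay, at which 1 of the 3 values shown sits.

Read against that limit, 2-methylprop-1-en-1-yl in place of propyl gives an at least 2.5-fold higher number from compound 2 to compound 3 (0.40 log units; beyond the scatter), so the chain on the oxygen can move the number upward from the propyl of compound 2 as well as downward, and propyl is no longer the poorest chain tried. With cyclopentyl in place of the same group the other way round, the comparison reads an at least 37-fold higher number from compound 1 to compound 3 (1.57 log units; beyond the scatter), and the three chains together show no simple rise in strength with chain size: compound 3 carries more carbon than compound 2 yet goes against such a trend, while compound 1 fits it.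

The compounds shown do not separate the double bond from the added methyl branch, a question that a saturated 3-methylbutyl chain on the oxygen would address directly. From the compounds shown here alone, how far the value of compound 3 lies past its limit stays unknown, and so does whether a cyclohexyl in place of cyclopentyl would extend the stronger end of the series.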